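Estimating a Ring-Free Side Chain Against Growth Inhibition

A few compounds are considered here, and "the series" means these few. Any claim that something is new, unique, unknown or untested is made for them only; others in the source may bear on it.

Three compounds have been measured in a functional assay on DU-145 cells (Homo sapiens) for antiproliferative activity, read by sulforhodamine B assay, with a stated time of 3 days (a higher number here means a weaker inhibitor of growth, a lower number a stronger inhibitor of growth), so far:
- Compound 1 `O=C(Nc1ccccn1)c1cccc(Nc2ncc(F)c(Nc3ccc(F)cc3)n2)c1` gives 15100 nM
- Compound 2 `CN(C)c1ccc(C(=O)Nc2cccc(Nc3ncc(F)c(Nc4ccc(F)cc4)n3)c2)cc1` gives > 10000 nM (a limit of the assay, not a number)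
- Compound 3 `Cn1ccnc1NC(=O)c1cccc(Nc2ncc(F)c(Nc3ccc(F)cc3)n2)c1` gives 15100 nM

In this assay compound 3 gives 15100 nM and stands level with compound 1 at the digits shown.

Compound 4 `CN(C)CC(=O)Nc1cccc(Nc2ncc(F)c(Nc3ccc(F)cc3)n2)c1` is the next to be measured. In it, (1-methyl-1H-imidazol-2-yl)carbamoyl leaves and (((dimethylamino)methyl)carbonyl)amino enters on the same aromatic carbon ((((dimethylamino)methyl)carbonyl)amino in place of (1-methyl-1H-imidazol-2-yl)carbamoyl on an aromatic carbon). The new group has no ring.

Within the data shown here, only one measured step bears on this change, and it shows no change at the digits printed from compound 1 to compound 3 (within the scatter) as 1-methyl-1H-imidazol-2-yl replaces pyridin-2-yl on an amide-type nitrogen. That swap keeps a ring, so it is only a loose guide to a change that removes one. On that evidence, no step beyond the scatter is expected in either direction. The expected step is a 1.0-fold lower number from compound 3 to compound 4 (0.00 log units; within the scatter) as a rough estimate. For compound 4 the expected value is 15000 nM with an estimated range from 5000 nM to 45000 nM in this wide band. A limit instead of a number is also possible for compound 4.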

Compound 4, concentration for 50% growth inhibition: 1210 nM
Compound 4: middle estimate off by 12-fold (1.09 log units), on the high side; measured number outside the range, below it.
By their numbers in this assay, from the lowest: compound 4; then compounds 1 and 3 (each within the scatter of the next).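

In this assay this position turns out to be sensitive: swapping one ring for another on the amide nitrogen moved nothing, but the ring-free (((dimethylamino)methyl)carbonyl)amino group brings a 12-fold lower number from compound 3 to compound 4 (1.10 log units; beyond the scatter) and also a 12-fold lower number from compound 1 to compound 4 (1.10 log units; beyond the scatter). Putting (dimethylamino)methyl in place of 4-(dimethylamino)phenyl on the carbonyl carbon points the same way, with an at least 8.2-fold lower number from compound 2 to compound 4 (0.91 log units; beyond the scatter). That last step starts from a limit for compound 2, not a number: the limit of > 10000 nM in this assay, at which 1 of the 4 values shown sits.

The compounds shown leave open whether the lower number belongs to the dimethylamino group or to the short ring-free chain that carries it. A pyrrolidine or morpholine in place of the dimethylamino group, or a longer carbon chain leading to it, would help to separate the two.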